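Adding a methoxy to a compound at the assay limit

The source may hold more compounds than are shown below. What is called first, only, known or untested is meant among the compounds shown, and "the series" means these compounds.

Measured so far in a functional assay on HT-29 cells (Homo sapiens) for cytotoxicity, read by MTT assay, with a stated time of 6 days (on this read-out higher numbers stand for an effect only at larger amounts of compound and lower numbers for an effect already at smaller amounts), all three as limits:
Compound 1 `COC(=O)c1c(-c2ccc([N+](=O)[O-])cc2)oc2cc(OC)ccc2c1=O` gives > 25 ug/mL as a limit
Compound 2 `COC(=O)c1c(-c2ccc(N)cc2)oc2ccccc2c1=O` gives > 25 ug/mL as a limit
Compound 3 `COC(=O)c1c(-c2ccc(O)cc2)oc2ccccc2c1=O` gives > 25 ug/mL as a limit

Compound 3 stands at > 25 ug/mL as a limit and not as a number. The data so far show the limit of > 25 ug/mL in this assay, at which 3 of the 3 values shown sit, and nothing finer. Going on to compound 4 `COC(=O)c1c(-c2ccc(O)cc2)oc2cc(OC)ccc2c1=O` brings one structural change, methoxy in place of hydrogen on an aromatic carbon. Within the data shown here, the one measured step is a step that the two limits leave unreadable from compound 2 to compound 3 and concerns a different change, so it offers no size to carry over. Compound 1 also carries a methoxy and shows > 25 ug/mL as a limit. In this assay no step beyond the usual scatter is therefore expected, in either direction. The expected step is a number no higher from compound 3 to compound 4 (the limit leaves the size open) as an estimate only. For compound 4 the estimated value is 25 ug/mL with an expected range from 10 ug/mL to 50 ug/mL on repeated measurement.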

Compound 4, concentration for half-maximal effect: 19.2 ug/mL
The estimate for compound 4 lay 1.3-fold (0.11 log units) above the measured number, within the range that was stated.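

Among these compounds, compound 4 is the first compound here to give a number rather than a limit in this assay, so this position on the shared core now has a readable value to compare against. Methoxy in place of hydrogen brings an at least 1.3-fold lower number from compound 3 to compound 4 (0.11 log units; that floor lies within the scatter), and hydroxy in place of nitro, with the methoxy present on both sides, brings an at least 1.3-fold lower number from compound 1 to compound 4 (0.11 log units; that floor lies within the scatter). Going by these compounds, the true size of both steps stays open, because each starts from a limit: the limit of > 25 ug/mL in this assay, at which 3 of the 4 values shown sit.

The compounds shown leave open whether a longer chain such as ethoxy, or a lone fluorine, at the same place would also give a number in this read-out. They also leave open how the amino group of compound 2 would behave with the methoxy present.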